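The source may hold more compounds than are shown below. What is called first, only, known or untested is meant among the compounds shown, and "the series" means these compounds.

Measured so far:
Compound 1, `COc1cccc2c1OCN(c1ccc3oc(-c4ccccc4)cc(=O)c3c1)C2`, in a functional assay on MCF7 cells (Homo sapiens) for inhibition, read by MTT assay, with a stated time of 48 h, tested at 30 ug/mL (a lower number here means less inhibition of growth, a higher number more inhibition of growth at the concentration tested), gives 67.8%.
Compound 2, `Cc1cccc2c1OCN(c1ccc3oc(-c4ccccc4)cc(=O)c3c1)C2`, in this assay gives 72.4%.

For the measured compounds named here, compound 2 stands at the higher of the two numbers in this assay, but its only neighbour is compound 1, and the step of a number 4.6 percentage points higher from compound 1 to compound 2 (within the scatter) lies within the scatter, so the two compounds cannot be told apart on these data.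

Compound 3, `O=c1cc(-c2ccccc2)oc2ccc(N3COc4c(cccc4[N+](=O)[O-])C3)cc12`, has not yet been measured. It differs from compound 2 by the change (nitro in place of methyl on an aromatic carbon). Going by the values given here, the only measured step, a number 4.6 percentage points higher from compound 1 to compound 2 (within the scatter), concerns a different exchange at the same kind of carbon and was too small to register beyond the scatter. Among the compounds with values here, no measured step bears on a nitro group at this place, so there is no ground for expecting a shift in this assay in either direction beyond the scatter. For compound 3 the expected value is therefore 70%, with a range from 50% to 85%, which means an expected step of a number 2.4 percentage points lower from compound 2 to compound 3 (within the scatter).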

Compound 3, percent growth inhibition at one concentration: 61.9%
Beside the measured number, compound 3's estimate is 8.1 percentage points above it, within the range that was stated.
By their numbers in this assay, from the lowest: compounds 3, 1 and 2 (each within the scatter of the next, the first and the last beyond it).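

In this assay, for the compounds shown here, the exchange of methyl for nitro on this aromatic carbon gives the first step that registers, a number 10.5 percentage points lower from compound 2 to compound 3 (beyond the scatter), so the group at this place can move the number, though only modestly. Nitro set against methoxy gives a number 5.9 percentage points lower from compound 1 to compound 3 (within the scatter), which leaves those two compounds indistinguishable, so of the three pairs only the one of methyl and nitro separates. No measurement at hand offers an explanation for this step.

What the compounds shown leave open is how an amine, a carboxylic acid or a longer chain on this same carbon would read in this assay. They also leave open whether the separation between methyl and nitro would hold at other concentrations, since each compound is read at a single one.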